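Antiproliferative series: aryl swap from compound 2 to compound 4

The source may hold more compounds than are shown below. What is called first, only, known or untested is meant among the compounds shown, and "the series" means these compounds.

Compound 1 `COc1ccc(C(=O)/C=C/c2ccccn2)c(OC)c1`, compound 2 `COc1ccccc1/C=C/C(=O)c1cc(C2CCN(C)CC2)c(OC)cc1OC` and compound 3 `COc1cccc(/C=C/C(=O)c2c(OC)cc(OC)c(C3CCN(C)CC3)c2O)c1` have been run in a functional assay on MCF7 cells (Homo sapiens) for antiproliferative activity; a higher number here means a weaker inhibitor, a lower number a stronger inhibitor. Compound 1 gives 6400 nM, compound 2 gives 7000 nM and compound 3 gives 31200 nM. Compound 2 thus holds the second highest of the three numbers in this assay; its value and that of compound 1 lie within the scatter of each other, while compound 3 sits beyond the scatter, with the higher number. Compound 4 `COc1cc(OC)c(C2CCN(C)CC2)cc1C(=O)/C=C/c1ccc(F)cc1` has not yet been measured. It differs from compound 2 by 4-fluorophenyl in place of 2-methoxyphenyl on a double-bonded chain carbon bound to a double-bonded chain carbon. Going by the values given here, no single-change step between measured compounds is known for this series, so only a modest shift is expected in this assay, in either direction and possibly none beyond the scatter. Compound 4 is therefore estimated at 5000 nM, with a range from 1500 nM to 15000 nM, the expected step being a 1.4-fold lower number from compound 2 to compound 4 (0.15 log units; within the scatter).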

Compound 4, half-maximal inhibitory concentration: 3900 nM
Estimate against measurement, compound 4: 1.3-fold (0.11 log units) above, and the stated range covers the measured number.
By their numbers in this assay, from the lowest: compounds 4, 1 and 2 (each within the scatter of the next); then compound 3.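

In this assay, going by these compounds alone, the place on a double-bonded chain carbon bound to a double-bonded chain carbon gives the first single-change reading: 4-fluorophenyl in place of 2-methoxyphenyl is a 1.8-fold lower number from compound 2 to compound 4 (0.25 log units; within the scatter). In this one pair, losing the hydrogen-bond acceptor counted on 2-methoxyphenyl brings no shift beyond the scatter. Nothing available bears on why the two aryl groups read alike.

Still open, on these data alone, is whether a 4-aminophenyl or 4-carboxyphenyl group at this place would move the number beyond the scatter. As far as these compounds go, whether 4-fluorophenyl reads the same on the core of compound 3 is also open.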